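Swapping the azide for a methoxy group on the sugar arm

The compounds below may be only part of what the source reports. "The series", "measured", "known", "first", "only" and "open" are said of these compounds alone.

Compound 1 `OCC1OC(SC/C=C/c2ccccc2)C(O)C(O)C1O`: in a functional assay (T-cell) for inhibition, with Cavia porcellus as the target, read by thymidine incorporation (on this read-out lower numbers stand for stronger inhibition and higher numbers for weaker inhibition), compound 1 gives 871000 nM.
Compound 2 `CC1OC(SC/C=C/c2ccccc2)C(O)C(O)C1O`: in this assay compound 2 gives 102000 nM; 160000 nM; 750000 nM; 525000 nM (4 entries).
Compound 3 `[N-]=[N+]=NCC1OC(SC/C=C/c2ccccc2)C(O)C(O)C1O`: in this assay compound 3 gives 240000 nM.

Compound 3 stands with the lowest single number among the compounds with one value; its nearest neighbour is compound 1, and the step of a 3.6-fold lower number from compound 1 to compound 3 (0.56 log units; beyond the scatter) shows how far apart they lie. Compound 2 has several entries, (the several entries of compound 2 in this assay, 102000 nM; 160000 nM; 750000 nM; 525000 nM (4 entries)), which spread widely and are not captured by one number. Compound 4 `COCC1OC(SC/C=C/c2ccccc2)C(O)C(O)C1O` carries the change (methoxy in place of azido on a saturated chain carbon bound to a saturated ring carbon). Going by the values given here, the only measured step at this position, a 3.6-fold lower number from compound 1 to compound 3 (0.56 log units; beyond the scatter), was modest and pointed towards a lower number when the azido group entered. Removing it again is expected to give back part of that gain, so a modest rise is expected: a 1.7-fold higher number from compound 3 to compound 4 (0.22 log units; within the scatter). Compound 4 is therefore estimated at 400000 nM, within a range from 120000 nM to 1300000 nM.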

Compound 4, half-maximal inhibitory concentration: 41000 nM
Beside the measured number, compound 4's estimate is 9.8-fold (0.99 log units) above it, outside the stated range (below it).
By their numbers in this assay, from the lowest: compound 4; then compound 3; then compound 1.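

In this assay the azido group proves unnecessary for a lower number at this position, since methoxy goes further, with a 5.9-fold lower number from compound 3 to compound 4 (0.77 log units; beyond the scatter). Measured against the free hydroxy, placing a methyl on that oxygen gives a 21-fold lower number from compound 1 to compound 4 (1.33 log units; beyond the scatter), the first large step seen at this position. Single readings still call for some caution, since repeat readings in the series spread widely: the several entries of compound 2 in this assay, 102000 nM; 160000 nM; 750000 nM; 525000 nM (4 entries)

On these data alone, whether a longer ether such as ethoxy, or an amine, would lower the number further remains open. The compounds shown also leave open whether the methoxy result holds up on repeat readings.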